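From methoxymethyl to hydroxymethyl on the shared core

The source may hold more compounds than are shown below. What is called first, only, known or untested is meant among the compounds shown, and "the series" means these compounds.

In a functional assay on KBVIN cells (Homo sapiens) for cytotoxicity, read by sulforhodamine B assay, with a stated time of 3 days (a higher number here means that more compound is needed for the effect, a lower number that less compound is needed), compound 1 (`Cc1coc(-c2ccc3c(c2O)CCCC3(C)C)c1CO`) gives 19.9 uM and compound 2 (`COCc1c(C)coc1-c1ccc2c(c1OC)CCCC2(C)C`) gives 20.1 uM, so these two values lie within the scatter of each other. Compound 3 (`COc1c(-c2occ(C)c2CO)ccc2c1CCCC2(C)C`) differs from compound 2 by hydrogen in place of methyl on an oxygen on a saturated carbon, methoxymethyl to hydroxymethyl (hydrogen in place of methyl on an oxygen on a saturated carbon). Among the measured compounds shown here, no pair of measured compounds differing in one place gives this change a size. The estimated step, a 1.0-fold lower number from compound 2 to compound 3 (0.00 log units; within the scatter), is expected to stay within the scatter in this assay, with no direction favoured. For compound 3 the expected value is 20 uM, with an estimated range of 10 uM to 40 uM.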

Compound 3, concentration for half-maximal effect: 21.7 uM
For compound 3 the middle estimate is 1.1-fold (0.04 log units) below the measured one; the measured number falls inside the stated range.
By their numbers in this assay, from the lowest: compounds 1, 2 and 3 (each within the scatter of the next).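

In this assay the change from methoxymethyl to hydroxymethyl on the shared core now has a measured size (with a 1.1-fold higher number from compound 2 to compound 3 (0.03 log units; within the scatter)), and it lies within the scatter. Methyl in place of hydrogen on an oxygen on an aromatic ring also has a size now (with a 1.1-fold higher number from compound 1 to compound 3 (0.04 log units; within the scatter)), likewise within the scatter. No measurement shown bears on why these numbers lie so close. The compounds shown leave open whether an amine or a carboxylic acid in place of the hydroxymethyl, or a longer chain on that oxygen, would give a step beyond the scatter.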